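Adding a Methyl to the Isopropyl of Compound 2

The source may report more compounds than this note shows. Statements on the series, on what has been measured and on what is new or still open speak of the compounds shown alone.

In a functional assay on cells (T-cell, Mus musculus) for inhibition (on this read-out lower numbers stand for stronger inhibition and higher numbers for weaker inhibition), compound 2 `CC(C)c1ccc(/C=C/C(=O)Nc2ccc3c(c2)COC3=O)cc1` gives the lowest of the two numbers, at 1590 nM. Compound 1 `N#Cc1ccc(/C=C/C(=O)Nc2ccc3c(c2)COC3=O)cc1` gives 43100 nM in this assay. Within the data shown here, the single measured step, a 27-fold lower number from compound 1 to compound 2 (1.43 log units; beyond the scatter), is large but is a different kind of change. Compound 3 `CC(C)(C)c1ccc(/C=C/C(=O)Nc2ccc3c(c2)COC3=O)cc1` differs from compound 2 by methyl in place of hydrogen on a saturated chain carbon bound to an aromatic carbon and two saturated chain carbons. Because that one step of a 27-fold lower number from compound 1 to compound 2 (1.43 log units; beyond the scatter) does not cover a methyl added in this way, it bears on the new step only loosely, and no change beyond the scatter is expected: a 1.3-fold lower number from compound 2 to compound 3 (0.12 log units; within the scatter). Compound 3 is therefore estimated at 1200 nM, between 400 nM and 4000 nM.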

Compound 3, half-maximal inhibitory concentration: 720 nM
The estimate for compound 3 lay 1.7-fold (0.22 log units) above the measured number; the range from low to high includes it.
By their numbers in this assay, from the lowest: compound 3; then compound 2; then compound 1.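

In this assay, the added methyl on the saturated chain carbon gives a 2.2-fold lower number from compound 2 to compound 3 (0.34 log units; beyond the scatter) and shows that turning isopropyl into tert-butyl still moves the number, though only modestly. Tert-butyl in place of the nitrile gives a 60-fold lower number from compound 1 to compound 3 (1.78 log units; beyond the scatter) and makes compound 3 the strongest inhibitor of the three. Nothing at hand explains either step. On these data alone, what remains open is whether a longer chain, a cyclopropyl ring or an amine on this aromatic carbon would lower the number further, and whether a group larger than tert-butyl would continue the trend.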